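The compounds below may be only part of what the source reports. "The series", "measured", "known", "first", "only" and "open" are said of these compounds alone.

Going by the values given here, compound 1 `N#Cc1cnc(NCc2cnccc2C(F)(F)F)cc1N[C@H]1C[C@@H](O)C1` is one of two compounds measured in an assay on isolated protein for inhibition of protein kinase C theta type (Homo sapiens), read by TR-FRET, with a stated time of 2 h (on this read-out higher numbers stand for weaker inhibition and lower numbers for stronger inhibition), where compound 1 gives 500 nM. The other, compound 2 `COc1ncncc1CNc1cc(N[C@H]2CC[C@@H](O)CC2)c(C#N)cn1`, gives 800 nM in this assay, a number within the scatter of that of compound 1, so the two stand together with no order between them. Compound 3 `CC1(C)C[C@H](Nc2cc(NCc3cnccc3C(F)(F)F)ncc2C#N)CC[C@@H]1O` has not been measured. It differs from compound 1 in one place: 4-hydroxy-3,3-dimethylcyclohexyl in place of 3-hydroxycyclobutyl on a nitrogen on an aromatic ring. Among the compounds with values here, no step between measured compounds that share this change is available, so the size of the step can only be expected, not read off. Compound 2 carries a six-membered hydroxy ring on the same nitrogen with a different arm, and its value sits close to compound 1; on that basis the change is expected to bring a small step, if any, toward stronger inhibition, a 1.4-fold lower number from compound 1 to compound 3 (0.15 log units; within the scatter). Compound 3 is therefore estimated at 350 nM in this assay, with a range from 120 nM to 1000 nM.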

Compound 3, half-maximal inhibitory concentration: 7 nM
Beside the measured number, compound 3's estimate is 50-fold (1.70 log units) above it, outside the stated range (below it).
By their numbers in this assay, from the lowest: compound 3; then compounds 1 and 2 (each within the scatter of the next).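

In this assay the change from 3-hydroxycyclobutyl to 4-hydroxy-3,3-dimethylcyclohexyl brings a 71-fold lower number from compound 1 to compound 3 (1.85 log units; beyond the scatter) with nothing else in the structure altered, a large step beyond the scatter. The earlier compounds shown here offered no step at this nitrogen, and this pair shows that the number responds strongly to the group it carries. Nothing available here bears on why the step is so large.

Going by these compounds, the change alters ring size and adds two methyl groups at once, so how a plain 4-hydroxycyclohexyl with the same arm would stand remains open, and with it how much of the step belongs to the larger ring and how much to the methyl groups. Also open, on these data alone, is what an amine or a methoxy group in place of the hydroxyl on the dimethylcyclohexyl ring would do.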